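The compounds below may be only part of what the source reports. "The series", "measured", "known", "first", "only" and "open" are said of these compounds alone.

Measured compounds in an ADME assay on microsomes from liver (Homo sapiens) for metabolic stability, tested at 2.5 uM; a higher number here means faster removal of the compound, a lower number slower removal:
- compound 1 `O=S(=O)(c1ccc(F)c(F)c1)c1cnc2c(F)cccc2c1-c1ccccc1F`, compound 1 gives 1.39 mL/min
- compound 2 `COc1cccc(-c2c(S(=O)(=O)c3cc(F)cc(F)c3)cnc3cc(F)ccc23)c1`, compound 2 gives 1.81 mL/min
- compound 3 `O=S(=O)(c1cc(Cl)cc(Cl)c1)c1cnc2c(F)cccc2c1-c1ccccc1F`, compound 3 gives 0.44 mL/min

Compound 1 stands second highest of the three numbers. Its nearest neighbour is compound 2, whose number is within the scatter of that of compound 1, so the two cannot be told apart. Among the measured compounds shown here, its furthest is compound 3, reached by a 3.2-fold lower number from compound 1 to compound 3 (0.50 log units; beyond the scatter), the one step in the set that is beyond the scatter; that step changes the group on the sulfonyl sulfur only.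

Compound 4 `O=S(=O)(c1ccc(F)c(F)c1)c1cnc2c(F)cccc2c1-c1cccc(Cl)c1` is not yet measured. It differs from compound 1 in one place: 3-chlorophenyl in place of 2-fluorophenyl on an aromatic carbon. For the measured compounds named here, no measured step touches this position. Going by the values given here, the single measured step, from compound 1 to compound 3, alters the sulfonyl aryl, and compound 2 differs from compound 1 in several places at once, so neither gives a direct read on swapping the group on the aromatic carbon. With nothing in the set speaking for a shift, no step beyond the scatter is expected in this assay for compound 4, in either direction; the expected step is a 1.0-fold higher number from compound 1 to compound 4 (0.00 log units; within the scatter). Compound 4 is estimated at 1.4 mL/min, with a range from 0.6 mL/min to 3 mL/min.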

Compound 4, intrinsic clearance in a liver preparation (reported as CLH), per the amount of preparation that the assay uses: 1.13 mL/min
Beside the measured number, compound 4's estimate is 1.2-fold (0.09 log units) above it, within the range that was stated.
By their numbers in this assay, from the lowest: compound 3; then compounds 4, 1 and 2 (each within the scatter of the next).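

In this assay, the one step shown at this position, 3-chlorophenyl in place of 2-fluorophenyl on an aromatic carbon, is a 1.2-fold lower number from compound 1 to compound 4 (0.09 log units; within the scatter), so this exchange of one halogen-bearing phenyl for another gives a change that cannot be told from the scatter. Among the compounds shown here, the position therefore accepts this particular swap without a resolved shift in the read-out, whereas the one step beyond the scatter in the set, a 3.2-fold lower number from compound 1 to compound 3 (0.50 log units; beyond the scatter), lies on the sulfonyl sulfur and says nothing about this aromatic carbon. Nothing at hand explains why the number holds for this pair.

On these data alone, both groups compared here are phenyl rings carrying a single halogen, so it stays open whether the number would hold with a phenyl bearing an amine or a carboxylic acid, or with a saturated ring or a longer chain on the same aromatic carbon. Also open, as far as these compounds go, is whether the 3-chlorophenyl group would keep the number unresolved from its partner when the sulfonyl sulfur carries the 3,5-dichlorophenyl group of compound 3 rather than the 3,4-difluorophenyl group of compound 1.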